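Notes on a chloro addition: compound 3 to compound 4

A few compounds are considered here, and "the series" means these few. Any claim that something is new, unique, unknown or untested is made for them only; others in the source may bear on it.

Measured so far, in a functional assay on MCF7 cells (Homo sapiens) for cytotoxicity, read by MTT assay, with a stated time of 72 h; on this read-out lower numbers stand for stronger inhibition and higher numbers for weaker inhibition:
compound 1 `COc1cccc(/C=C2\CCC/C(=C\c3cccc(OC)c3OC)C2=O)c1`: 5900 nM
compound 2 `COc1cccc(/C=C2\CCC/C(=C\c3cc(OC)c(OC)c(OC)c3)C2=O)c1OC`: 1400 nM
compound 3 `COc1ccc(/C=C2\CCC/C(=C\c3ccccc3Cl)C2=O)cc1OC`: 10400 nM

Of the three numbers in this assay, compound 3 shows the highest. Its gap to compound 1 lies within the scatter, so the two cannot be told apart; its gap to compound 2 lies beyond the scatter, with compound 2 giving the lower number of the pair.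

Compound 4 `COc1ccc(/C=C2\CCC/C(=C\c3cccc(Cl)c3Cl)C2=O)cc1OC` is not yet measured. It differs from compound 3 in one place, (chloro in place of hydrogen on an aromatic carbon). Among the measured compounds shown here, no step between two measured compounds shows this particular change, so there is no measured step to lean on; the three measured compounds differ from each other in several places at once. Given a change of one heavy atom on the ring, the expected step is small, with no clear direction beyond the scatter. Compound 4 is expected to come out near compound 3, with the step of a 1.3-fold lower number from compound 3 to compound 4 (0.11 log units; within the scatter). The estimate for compound 4 is 8000 nM, in the range 3000 nM to 22000 nM.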

Compound 4, half-maximal inhibitory concentration: 14300 nM
Estimate against measurement, compound 4: 1.8-fold (0.25 log units) below; measured number inside the range.
By their numbers in this assay, from the lowest: compound 2; then compounds 1, 3 and 4 (each within the scatter of the next, the first and the last beyond it).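

In this assay, among the compounds shown here, this is the first comparison that isolates a single change: 2-chlorophenyl to 2,3-dichlorophenyl gives a 1.4-fold higher number from compound 3 to compound 4 (0.14 log units; within the scatter) and stays within the scatter. For the compounds shown here, a second chloro on this aromatic carbon, ortho to the existing chloro group, therefore gives no step that can be told apart from repeat measurement, at least with the methoxy pattern that compound 3 carries on the other side of the core. No measured evidence on the cause bears on this result.

As far as these compounds go, it remains open whether a different group at this position, such as an amine or a carboxylic acid, would give a step beyond the scatter. From the compounds shown here alone, it is also open whether the same chloro addition would read alike with the methoxy pattern of compound 2 on the other aromatic ring.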